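Selenocyanate Carbamates: Dropping the Methoxy Group

A few compounds are considered here, and "the series" means these few. Any claim that something is new, unique, unknown or untested is made for them only; others in the source may bear on it.

Going by the values given here, compound 1 `COc1ccc(OC(=O)Nc2ccc([Se]C#N)cc2)cc1` stands at the lower of the two numbers so far, though the gap to its neighbour is within the scatter. In a functional assay on HT-29 cells (Homo sapiens) for cytotoxicity, read by MTT assay, with a stated time of 72 h (a higher number here means a weaker inhibitor of growth, a lower number a stronger inhibitor of growth), compound 1 gives 13600 nM. Compound 2 `O=C(Nc1ccc([Se][Se]c2ccc(NC(=O)OCc3ccc([N+](=O)[O-])cc3)cc2)cc1)OCc1ccc([N+](=O)[O-])cc1` gives 16700 nM in this assay. Compound 3 `N#C[Se]c1ccc(NC(=O)Oc2ccccc2)cc1` is still to be measured. The change from compound 1 to compound 3: hydrogen in place of methoxy on an aromatic carbon. Among the compounds with values here, no measured pair covers a comparable change, so no step beyond the scatter is expected in either direction. The expected step is a 1.0-fold higher number from compound 1 to compound 3 (0.01 log units; within the scatter). Compound 3 is estimated at 14000 nM, with a range from 5000 nM to 40000 nM.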

Compound 3, concentration for 50% growth inhibition: 11700 nM
Estimate against measurement, compound 3: 1.2-fold (0.08 log units) above; measured number inside the range.
By their numbers in this assay, from the lowest: compounds 3, 1 and 2 (each within the scatter of the next).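

Hydrogen in place of methoxy on an aromatic carbon, para to a large group, gives a 1.2-fold lower number from compound 1 to compound 3 (0.07 log units; within the scatter) in this assay on this series. Going by these compounds alone, this is the first one-place comparison, and it shows that the methoxy group can be removed from this position without a step beyond the scatter. No measurement on hand gives an explanation for this result.

Going by these compounds, whether an amine, a carboxylic acid or a longer alkoxy chain on this carbon would give a step beyond the scatter remains open.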